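Aryl Swap on the Ring Nitrogen: Expectation for Compound 3

The compounds below may be only part of what the source reports. "The series", "measured", "known", "first", "only" and "open" are said of these compounds alone.

Measured compounds:
compound 1 `CNC(=O)c1cc(Oc2ccc(NC(=O)c3nn(-c4ccc(Br)cc4F)c(=O)cc3C)cc2F)ccn1` — 9360 nM
compound 2 `CNC(=O)c1cc(Oc2ccc(NC(=O)c3nn(-c4ccc(C)cc4)c(=O)cc3C)cc2F)ccn1` — 8380 nM

In a functional assay on MCF7 cells (Homo sapiens) for cytotoxicity, read by MTT assay, with a stated time of 72 h (on this read-out lower numbers stand for stronger inhibition and higher numbers for weaker inhibition), compound 1 gives 9360 nM and compound 2 gives 8380 nM. Compound 2 thus holds the lowest of the two numbers, but the step of a 1.1-fold lower number from compound 1 to compound 2 (0.05 log units; within the scatter) is within the scatter, so the two compounds cannot be ranked against each other. Compound 3 `CNC(=O)c1cc(Oc2ccc(NC(=O)c3nn(-c4ccccc4F)c(=O)cc3C)cc2F)ccn1` differs from compound 2 by 2-fluorophenyl in place of 4-methylphenyl on an aromatic nitrogen. Among the measured compounds shown here, the only measured step that bears on this position is a 1.1-fold lower number from compound 1 to compound 2 (0.05 log units; within the scatter), which exchanged the group on the same aromatic nitrogen and left the number essentially unchanged; compound 1 already carried a fluorine on that ring. On this basis no step beyond the scatter is expected in either direction for compound 3. Compound 3 is therefore estimated at 9000 nM, with a range from 4000 nM to 20000 nM. The expected step is a 1.1-fold higher number from compound 2 to compound 3 (0.03 log units; within the scatter).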

Compound 3, half-maximal inhibitory concentration: > 40000 nM
Compound 3: only a limit was reported (the forecaster's own chance of this, stated with the estimate: 10%); at least 4.4-fold (0.64 log units) between middle value and limit.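

In this assay, the aryl group on this aromatic nitrogen proves not to be freely exchangeable, as 2-fluorophenyl in place of 4-methylphenyl gives an at least 4.7-fold higher number from compound 2 to compound 3 (0.67 log units; beyond the scatter). Hydrogen in place of bromo on that same aryl group gives an at least 4.2-fold higher number from compound 1 to compound 3 (0.63 log units; beyond the scatter), and since compound 1 and compound 3 both carry the fluorine, the fluorine alone does not separate them. Compound 1 and compound 2, one with a bromo and the other with a methyl on this aryl group, stand within the scatter of each other, whereas compound 3, with neither, does not.

As far as these compounds go, how far compound 3 lies beyond the others cannot be read, because its value is only a limit: the limit of > 40000 nM in this assay, at which 1 of the 3 values shown sits. Whether a methyl, an amine or a carboxylic acid in place of the bromo on the 2-fluorophenyl group would bring the number back remains open.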